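The source may report more compounds than this note shows. Statements on the series, on what has been measured and on what is new or still open speak of the compounds shown alone.

Compound 1 `Cc1ccc(C(=O)N[C@@H](C(=O)N2CCC(c3ccc(Cl)cc3)CC2)C(C)C)cc1`: 25 nM
Compound 2 `CC(C)(C)C(NC(=O)c1ccccc1)C(=O)N1CCC(c2ccc(Cl)cc2)CC1`: 259 nM

Among the measured compounds shown here, in an assay on THP-1 cells for displacement of a labelled ligand from C-C chemokine receptor type 1 (Homo sapiens) (a higher number here means a weaker inhibitor, a lower number a stronger inhibitor), compound 1 holds the lower of the two numbers; the only other measured member, compound 2, gives a higher number, a gap beyond the scatter. Compound 3 `CC(C)CC(=O)N[C@@H](C(=O)N1CCC(c2ccc(Cl)cc2)CC1)C(C)C` differs from compound 1 in one place: isobutyl in place of 4-methylphenyl on a carbonyl carbon. For the measured compounds named here, no measured pair shares this change, so its size is not known from the data. With the aromatic group gone from the acyl end, a weaker inhibitor is expected, a step beyond the scatter in this assay. For compound 3 the estimated step of a 6.0-fold higher number from compound 1 to compound 3 (0.78 log units; beyond the scatter) gives an expected value of 150 nM, within 40 nM to 600 nM.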

Compound 3, half-maximal inhibitory concentration: 32 nM
Compound 3: middle estimate off by 4.7-fold (0.67 log units), on the high side; the measured number lies below the stated range.
By their numbers in this assay, from the lowest: compounds 1 and 3 (each within the scatter of the next); then compound 2.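

In this assay isobutyl in place of 4-methylphenyl on a carbonyl carbon gives a 1.3-fold higher number from compound 1 to compound 3 (0.11 log units; within the scatter) and so leaves the number unmoved within the scatter. For this pair, the six-membered aromatic ring at this position is not required for a value in the range of compound 1, and a group without a ring serves equally. Nothing measured bears on the reason for this result. Going by these compounds, whether an amine, a carboxylic acid or a longer chain on this carbonyl carbon would keep the number remains open. Also open, on these data alone, is whether isobutyl and 4-methylphenyl would still match on a different core.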